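The source may report more compounds than this note shows. Statements on the series, on what has been measured and on what is new or still open speak of the compounds shown alone.

Compound 1 `O=C(N[C@@H]1CNCC[C@H]1c1ccc(Cl)cc1)c1ccc(-c2ncnc3c2CCC3O)s1` gives 23000 nM in a functional assay on HCT-116 cells (Homo sapiens) for antiproliferative activity, read by sulforhodamine B assay, with a stated time of 72 h; a higher number here means a weaker inhibitor, a lower number a stronger inhibitor.
Compound 2 `CC(=O)OCC[C@@H]1C[C@@H](c2ccc(F)c(F)c2)[C@H](NC(=O)c2cc(-c3c(Cl)cnn3C)c(Cl)o2)CN1` gives 690 nM in this assay.
Compound 3 `Cn1ncc(Cl)c1-c1cc(C(=O)N[C@@H]2CN[C@H](CC(N)=O)C[C@H]2c2ccc(Cl)c(Cl)c2)oc1Cl` gives 650 nM in this assay.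

Compound 3 has the lowest of the three numbers. Compound 2 sits so close that the two cannot be told apart within the scatter, whereas compound 1 lies far higher, well beyond it. Compound 4 `Cn1ncc(Cl)c1-c1cc(C(=O)N[C@@H]2CN[C@H](CCCO)C[C@H]2c2ccc(Cl)c(Cl)c2)oc1Cl` differs from compound 3 in one place: 2-hydroxyethyl in place of carbamoyl on a saturated chain carbon bound to a saturated ring carbon. The chain keeps one donor and one acceptor, and compound 2, which carries a different oxygen-bearing chain at the same place, stays level with compound 3 in this assay, so the step from compound 3 to compound 4 is expected to be small, of no clear direction, and within the scatter a 1.1-fold higher number from compound 3 to compound 4 (0.03 log units; within the scatter). Compound 4 is thus estimated at 700 nM, between 300 nM and 1600 nM.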

Compound 4, half-maximal inhibitory concentration: 510 nM
The estimate for compound 4 lay 1.4-fold (0.14 log units) above the measured number; the range from low to high includes it.
By their numbers in this assay, from the lowest: compounds 4, 3 and 2 (each within the scatter of the next); then compound 1.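

At the place on a saturated chain carbon bound to a saturated ring carbon, 2-hydroxyethyl in place of carbamoyl gives a 1.3-fold lower number from compound 3 to compound 4 (0.11 log units; within the scatter) in this assay. At this place, therefore, the carbamoyl group, with its nitrogen and its double bond, can be exchanged for 2-hydroxyethyl with no change beyond the scatter. No measurement shown here gives a reason for this result. From the compounds shown here alone, whether an amine or a carboxylic acid at the end of this chain, or a longer chain, would keep the number in the same range remains open.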